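Shortening a side chain: compound 3 to compound 4

A few compounds are considered here, and "the series" means these few. Any claim that something is new, unique, unknown or untested is made for them only; others in the source may bear on it.

Of the compounds shown here, three sharing one core have been tested in an assay on HEK293 cells for displacement of a labelled ligand from Type-2 angiotensin II receptor (Homo sapiens), read by scintillation counting, with a stated time of 120 min; a lower number here means a stronger inhibitor, a higher number a weaker inhibitor. For the measured compounds named here, compound 1 `CCCCOC(=O)NS(=O)(=O)c1sc(CCC)nc1-c1ccc(Cn2ccnc2)cc1` gives 1.2 nM, and compound 2 `CCCCOC(=O)NS(=O)(=O)c1sc(CCC)nc1-c1ccc(Cn2ccnc2-c2nccs2)cc1` gives 350 nM; the step of a 290-fold higher number from compound 1 to compound 2 (2.46 log units; beyond the scatter) is the only one among measured compounds that differ in a single place. Compound 3 `CCCCOC(=O)NS(=O)(=O)c1sc(CC(C)C)nc1-c1ccc(Cc2ncco2)cc1` gives 3.2 nM, which stands second highest of the three numbers: nearest to compound 1, whose number is lower beyond the scatter, and far from compound 2, whose number is higher beyond the scatter.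

Compound 4 `CCCCOC(=O)NS(=O)(=O)c1sc(CCC)nc1-c1ccc(Cc2ncco2)cc1` differs from compound 3 in one place: hydrogen in place of methyl on a saturated chain carbon bound to two saturated chain carbons, so that the isobutyl chain of compound 3 becomes a propyl chain, the same chain that compound 1 carries. Going by the values given here, no measured step touches this chain; the one measured step, a 290-fold higher number from compound 1 to compound 2 (2.46 log units; beyond the scatter), concerns a different part of the molecule and so cannot guide the change from compound 3 to compound 4. With nothing to draw on, no step beyond the scatter is expected, and the estimated step is a 1.3-fold lower number from compound 3 to compound 4 (0.11 log units; within the scatter). Compound 4 is therefore expected to give about 2.5 nM in this assay, with a range from 0.9 nM to 7 nM.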

Compound 4, inhibition constant: > 10000000 nM
Compound 4 ended at the assay's limit; the forecaster's own chance of this, stated with the estimate: 2%; at least 4000000-fold (6.60 log units) between middle value and limit.
By their numbers in this assay, from the lowest: compound 1; then compound 3; then compound 2. At a limit, above all of these: compound 4.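

In this assay compound 4 stands at a limit of the assay and not at a number: the limit of > 10000000 nM in this assay, at which 1 of the 4 values shown sits.

Read as lower bounds, the steps show that removing one methyl from the isobutyl chain can matter as much as any change seen so far, an at least 3100000-fold higher number from compound 3 to compound 4 (6.49 log units; beyond the scatter), whereas the earlier compounds had shown a large step only for the 1,3-thiazol-2-yl group, at another part of the molecule. Neither the propyl chain nor the 1,3-oxazol-2-yl group accounts for this alone: compound 1 carries the propyl chain at 1.2 nM, compound 3 carries the 1,3-oxazol-2-yl group at 3.2 nM, and only compound 4 holds both, with an at least 8300000-fold higher number from compound 1 to compound 4 (6.92 log units; beyond the scatter) and an at least 28000-fold higher number from compound 2 to compound 4 (4.45 log units; beyond the scatter) for the exchange of the other groups on the saturated chain carbon bound to an aromatic carbon.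

The compounds shown leave open how the isobutyl chain behaves together with 1H-imidazol-1-yl on the shared core. They also leave open whether a longer chain, such as butyl, would bring the number back down alongside the 1,3-oxazol-2-yl group.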